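Swapping Two Chlorines for Two Fluorines on the Aryl Ketone

The source may report more compounds than this note shows. Statements on the series, on what has been measured and on what is new or still open speak of the compounds shown alone.

Three close relatives share one core and were tested in a functional assay on SK-OV-3 cells (Homo sapiens) for cytotoxicity, read by sulforhodamine B assay, with a stated time of 48 h, tested at 0.01 uM; on this read-out lower numbers stand for a stronger effect and higher numbers for a weaker effect at the one concentration tested. Compound 1, `COc1cc(-c2cc(/C=C/C(=O)c3ccc(Cl)c(Cl)c3)[nH]n2)cc(OC)c1OC`, gives 99%. Compound 2, `COc1ccc(-c2cc(/C=C/C(=O)c3cc(OC)c(OC)c(OC)c3)[nH]n2)cc1OC`, gives 97%, and compound 3, `COc1cc(C(=O)/C=C/c2cc(-c3cc(OC)c(OC)c(OC)c3)n[nH]2)cc(OC)c1OC`, gives 100%. All three numbers lie within the usual scatter of one another, so compound 1 cannot be separated from either neighbour: its gap to compound 3 and its gap to compound 2 are both within the scatter. Among the compounds with values here, the only single change among the measured compounds is the methoxy in place of hydrogen on an aromatic carbon, which gave a number 3 percentage points higher from compound 2 to compound 3 (within the scatter).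

Compound 4, `COc1cc(-c2cc(/C=C/C(=O)c3ccc(F)c(F)c3)[nH]n2)cc(OC)c1OC`, differs from compound 1 in one place: 3,4-difluorophenyl in place of 3,4-dichlorophenyl on a carbonyl carbon. Within the data shown here, no measured step touches this kind of exchange, and the one step that is known did not move the read-out beyond the scatter. With every measured compound sitting at nearly the same high number, nothing here points to a shift in either direction.

The expected step of a number 1 percentage points lower from compound 1 to compound 4 (within the scatter) is therefore estimated to stay within the scatter. Compound 4 is expected to give about 98%, with a range from 88% to 105%.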

Compound 4, a percentage reported as activity, at one concentration (the size of the read-out at that concentration, not a potency): 98%
For compound 4 middle estimate and measured number coincide at the digits printed, and the stated range covers the measured number.
By their numbers in this assay, from the lowest: compounds 2, 4, 1 and 3 (each within the scatter of the next).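

In this assay, putting 3,4-difluorophenyl in place of 3,4-dichlorophenyl on a carbonyl carbon gives a number 1 percentage points lower from compound 1 to compound 4 (within the scatter). This is the first single change shown for the group on the carbonyl carbon, since the only earlier step, methoxy in place of hydrogen on an aromatic carbon, left that group as it was, and at the one concentration tested the difluoro and dichloro forms cannot be told apart. No separate measurement offers an explanation for this result.

With all four compounds so close together, this single concentration says little about how the two halogen pairs would compare under conditions where the compounds give a clearly stronger effect. It also leaves open whether a different kind of group on that phenyl ring, such as an amine or a carboxylic acid in place of the two halogens, would move the read-out beyond the usual scatter of repeated measurements.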